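The source may report more compounds than this note shows. Statements on the series, on what has been measured and on what is new or still open speak of the compounds shown alone.

Measured compounds:
compound 1 `COc1cc(-c2cc(/C=C/C(=O)c3ccc(N)cc3)[nH]n2)cc(OC)c1OC`, 90%
compound 2 `COc1ccc(-c2cc(/C=C/C(=O)c3ccc(OC)c(OC)c3)[nH]n2)cc1`, 90%
compound 3 `COc1ccc(-c2cc(/C=C/C(=O)c3cc(OC)c(OC)c(OC)c3)[nH]n2)cc1OC`, 89%

In a functional assay on SK-MEL-28 cells (Homo sapiens) for cytotoxicity, read by sulforhodamine B assay, with a stated time of 48 h, tested at 1 uM (on this read-out lower numbers stand for a stronger effect and higher numbers for a weaker effect at the one concentration tested), compound 1 gives 90%. Compound 2 gives 90% and compound 3 gives 89%. The three numbers lie within the scatter of one another, so no order can be read among them; compound 1 merely shares the highest printed figure with compound 2, and compound 3 sits a hair lower at the digits shown, which means nothing here. All three compounds therefore show only a weak effect at the single concentration tested.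

Compound 4 `COc1ccc(C(=O)/C=C/c2cc(-c3cc(OC)c(OC)c(OC)c3)n[nH]2)cc1` has not yet been measured. It differs from compound 1 in one place: methoxy in place of amino on an aromatic carbon. For the measured compounds named here, no step between two measured compounds is available to weigh this change. What the measured set does show is that compounds differing in their aryl substituents all sit at the same level in this assay, and there is nothing in those numbers to suggest that this change would move compound 4 away from that level. The step of a number 1 percentage points lower from compound 1 to compound 4 (within the scatter) is expected to be none beyond the scatter. Compound 4 is accordingly estimated to give 89%, in a range from 78% to 100%.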

Compound 4, a percentage reported as activity, at one concentration (the size of the read-out at that concentration, not a potency): 101%
For compound 4 the middle estimate is 12 percentage points below the measured one, outside the stated range (above it).
By their numbers in this assay, from the lowest: compounds 3, 1 and 2 (each within the scatter of the next); then compound 4.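

In this assay, for the compounds shown here, methoxy in place of amino on an aromatic carbon, para to a large group, gives a step of a number 11 percentage points higher from compound 1 to compound 4 (beyond the scatter), the first change in this set that can be read beyond the scatter. Going by these compounds alone, this shows that the position is not indifferent to what it carries, a point the earlier compounds could not show, as none of them formed a one-place pair. Since higher numbers stand for a weaker effect, the amino group of compound 1 holds a modest edge over methoxy, although compound 1 at 90% still shows only a weak effect, and nothing available explains the difference between the two groups.

As far as these compounds go, whether a hydroxyl or a dimethylamino group at this place would read like amino or like methoxy remains open. Also open, from the compounds shown here alone, is whether the same exchange would give a similar step on the aryl ring at the other end of the shared core.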